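A few compounds are considered here, and "the series" means these few. Any claim that something is new, unique, unknown or untested is made for them only; others in the source may bear on it.

Working notes on the series. Exposure was followed in an ADME assay on the whole organism (Macaca fascicularis) for pharmacokinetics, read by LC-MS, using cassette dosing, at a dose of 1 mg/kg by the oral route; a higher number here means more compound in the circulation at the dose given, a lower number less compound in the circulation. Compound 1 `C[C@H](c1ccc(-c2ccccc2-c2nc(=O)o[nH]2)cc1)N(CC1CC1)c1nc2c(C(=O)O)cccc2o1` gives 11600 ng.h/mL in this assay. Compound 2 `CCCCN(c1nc2c(C(=O)NC)cccc2o1)[C@H](C)c1ccc(-c2ccccc2-c2nnn[nH]2)cc1` gives 25.7 ng.h/mL in this assay. Compound 3 `CCCCN(c1nc2c(C(=O)O)cccc2o1)[C@H](C)c1ccc(-c2cc(Cl)ccc2-c2nc(=O)o[nH]2)cc1` gives 1040 ng.h/mL in this assay. Of the three numbers, compound 2 stands lowest; compound 3 is nearest to it, and compound 1 furthest, both gaps lying well beyond the scatter of repeated measurements. These three compounds differ from one another in several places at once, so no single change can be read off from their values.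

The next compound, compound 4 `CCCCN(c1nc2c(C(=O)N(C)C)cccc2o1)[C@H](C)c1ccc(-c2ccccc2-c2nnn[nH]2)cc1`, differs from compound 2 in exactly one place: methyl in place of hydrogen on an amide-type nitrogen. Among the compounds with values here, no pair of measured compounds shows this change, so there is no measured step to lean on. Both compounds carry the tetrazole and the four-carbon chain of compound 2, and the only point of difference is the second methyl on the amide nitrogen. The expected step from compound 2 to compound 4 is a 1.9-fold higher number from compound 2 to compound 4 (0.29 log units; within the scatter), a small rise that stays close to the scatter. Compound 4 is accordingly estimated at 50 ng.h/mL in this assay, with a range from 10 ng.h/mL to 250 ng.h/mL.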

Compound 4, area under the concentration-time curve: 104 ng.h/mL
Beside the measured number, compound 4's estimate is 2.1-fold (0.32 log units) below it, within the range that was stated.
By their numbers in this assay, from the lowest: compound 2; then compound 4; then compound 3; then compound 1.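

Methyl in place of hydrogen on the amide-type nitrogen gives a 4.0-fold higher number from compound 2 to compound 4 (0.61 log units; beyond the scatter) in this assay, the first change in the series that can be read on its own. The step is modest but lies beyond the scatter, so the methylcarbamoyl to dimethylcarbamoyl change at this position registers in this read-out, and the amide hydrogen can be replaced without a loss of exposure in this pair. The reading rests on this single pair, which carries the tetrazole and the four-carbon chain, and nothing measured here accounts for the size or direction of the step.

From the compounds shown here alone, whether ethyl or a longer chain on this amide-type nitrogen would continue the rise, hold it or reverse it remains open. Also open, going by these compounds, is whether the same methyl-for-hydrogen change gives a step of similar size when an amine or an ether-bearing chain replaces the four-carbon chain of compound 4.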